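Amide aryl variation on the bis-benzylidene piperidinone series

The compounds below may be only part of what the source reports. "The series", "measured", "known", "first", "only" and "open" are said of these compounds alone.

Compound 1 `O=C(/C=C/C(=O)N1C/C(=C\c2ccccc2)C(=O)/C(=C/c2ccccc2)C1)Nc1ccc(Cl)c(Cl)c1` carries a 3,4-dichlorophenyl amide and gives 350 nM in a functional assay on CCRF-CEM cells (Homo sapiens) for cytotoxicity; on this read-out higher numbers stand for weaker inhibition and lower numbers for stronger inhibition. Compound 2 `Cc1ccc(NC(=O)/C=C/C(=O)N2C/C(=C\c3ccc([N+](=O)[O-])cc3)C(=O)/C(=C/c3ccc([N+](=O)[O-])cc3)C2)cc1C`, with nitro-substituted benzylidene arms and a 3,4-dimethylphenyl amide, gives 700 nM in this assay. Compound 3 `Cc1cccc(C)c1NC(=O)/C=C/C(=O)N1C/C(=C\c2ccc([N+](=O)[O-])cc2)C(=O)/C(=C/c2ccc([N+](=O)[O-])cc2)C1` keeps the same core and arms and gives 230 nM in this assay. Among the three numbers shown, compound 3 has the lowest; compound 1 sits nearest, within the scatter, and compound 2 furthest, beyond the scatter. For the measured compounds named here, the only single-point step so far is a 3.0-fold lower number from compound 2 to compound 3 (0.48 log units; beyond the scatter), a modest change on moving the methyl pattern of the amide aryl group.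

Compound 4 `Cc1ccc(NC(=O)/C=C/C(=O)N2C/C(=C\c3ccc([N+](=O)[O-])cc3)C(=O)/C(=C/c3ccc([N+](=O)[O-])cc3)C2)cc1` is the next member: 4-methylphenyl in place of 2,6-dimethylphenyl on an amide-type nitrogen. Going by the values given here, the one step that bears on this change runs in the other direction, from a 3,4-dimethylphenyl to a 2,6-dimethylphenyl, and lowered the number. Going from compound 3 to compound 4 moves away from the 2,6-dimethylphenyl, so a higher number is expected, though the 4-methylphenyl is not the same as the 3,4-dimethylphenyl of compound 2, so the expected size is taken as somewhat smaller than that step, a 2.0-fold higher number from compound 3 to compound 4 (0.29 log units; within the scatter). Compound 4 is therefore estimated at 450 nM in this assay, within a range of 220 nM to 950 nM.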

Compound 4, half-maximal inhibitory concentration: 890 nM
Beside the measured number, compound 4's estimate is 2.0-fold (0.30 log units) below it, and the stated range covers the measured number.
By their numbers in this assay, from the lowest: compounds 3, 1, 2 and 4 (each within the scatter of the next, the first and the last beyond it).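

In this assay, the lower number of compound 3 now stands against two other methyl-bearing amide aryl groups on the same nitro-substituted arms rather than one: moving to 4-methylphenyl gives a 3.9-fold higher number from compound 3 to compound 4 (0.59 log units; beyond the scatter), beyond the scatter and of modest size. The 3,4-dimethylphenyl and 4-methylphenyl amides do not separate, since hydrogen in place of methyl on an aromatic carbon gives a 1.3-fold higher number from compound 2 to compound 4 (0.10 log units; within the scatter), within the scatter, so among these three compounds only the 2,6-dimethylphenyl stands apart. Nothing available explains either step.

Compound 1 differs from the other three in both the arms and the amide aryl group, so it does not show whether the 2,6-dimethylphenyl advantage holds on unsubstituted benzylidene arms or how the 3,4-dichlorophenyl ranks on nitro-substituted ones. The shown set also leaves open how a plain phenyl, a methoxy-substituted phenyl or a phenyl bearing a carboxylic acid or an amine would compare on this amide nitrogen with the methyl-bearing groups.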